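This account rests on a few compounds, and the source may have more. Where it says the series, first, only, none or still open, it means among the compounds named here.

Measured in a functional assay on the whole organism for inhibition, with Rattus norvegicus as the target; a lower number here means that less compound is needed, a higher number that more compound is needed for the effect:
- compound 1 `CC(C)c1ccc(OC(C)(Cc2cccc(C(F)(F)F)c2)C(=O)O)cc1`: 5 mg/kg
- compound 2 `Cc1cccc(CC(C)(Oc2ccc(C(C)C)cc2)C(=O)O)c1`: < 1 mg/kg
- compound 3 `CCCc1cccc(CC(C)(Oc2ccc(C(C)C)cc2)C(=O)O)c1`: 1 mg/kg

The reading for compound 2 of < 1 mg/kg is a limit of the assay and not a number. This is the limit of < 1 mg/kg in this assay, at which 1 of the 3 values shown sits.

Compound 4 `CC(C)c1ccc(OC(C)(Cc2ccc(Cl)c(Cl)c2)C(=O)O)cc1` is still to be measured. It carries 3,4-dichlorophenyl in place of 3-methylphenyl on a saturated chain carbon, two bonds along the chain from a carbonyl carbon and an oxygen on an aromatic ring.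

Among the measured compounds shown here, three measured steps concern substituents on this same ring. The first is an at least 5.0-fold lower number from compound 1 to compound 2 (0.69 log units; beyond the scatter), and the second is a 5.0-fold lower number from compound 1 to compound 3 (0.70 log units; beyond the scatter). The third, a number no lower from compound 2 to compound 3 (the limit leaves the size open), leaves its size open. For the measured compounds named here, compound 1, the only measured compound with halogen atoms on this ring, therefore has the higher number, and the two alkyl compounds lie lower. Going by the values given here, no measured compound carries chlorine, so this is only a loose guide.

A modest move towards a higher number is expected, of about the size of an at least 5.0-fold lower number from compound 1 to compound 2 (0.69 log units; beyond the scatter) taken in reverse. The expected step is an at least 3.0-fold higher number from compound 2 to compound 4 (0.47 log units; beyond the scatter). For compound 4 the estimate is 3 mg/kg, with an expected range of 0.8 mg/kg to 10 mg/kg.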

Compound 4, dose for half-maximal effect: 5 mg/kg
Compound 4: middle estimate off by 1.7-fold (0.22 log units), on the low side; measured number inside the range.
By their numbers in this assay, from the lowest: compound 3; then compounds 1 and 4 (each within the scatter of the next).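

Among the compounds shown here, exchanging 3-methylphenyl for 3,4-dichlorophenyl on a saturated chain carbon, two bonds along the chain from a carbonyl carbon and an oxygen on an aromatic ring, gives an at least 5.0-fold higher number from compound 2 to compound 4 (0.69 log units; beyond the scatter) in this assay, the first reading for chlorine on this ring. In the same assay, compound 1 with its trifluoromethyl group gives 5 mg/kg and compound 4 gives 5 mg/kg, so the two halogen-bearing compounds read alike. The reading for compound 2 is a limit and not a number, so the true size of that step stays unknown: the limit of < 1 mg/kg in this assay, at which 1 of the 4 values shown sits.

Nothing shown separates the two chlorines, so the share of each in the step stays open. From the compounds shown here alone, how a ring with a single chlorine, a methoxy group or an amine would read at this position also stays open.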